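Methylpiperazine Replaces a Hydrogen on the Sulfonamide Ring

The source may report more compounds than this note shows. Statements on the series, on what has been measured and on what is new or still open speak of the compounds shown alone.

Compound 1 `COc1ccc(S(=O)(=O)NCCN2CCC(CCC(=O)c3cc(Cl)c(N)cc3OC)CC2)cc1` was tested in an assay on brain for displacement of a labelled ligand from 5-hydroxytryptamine receptor 4 (Cavia porcellus), with a stated time of 30 min, in the presence of a further agent that is not named here (a lower number here means a stronger inhibitor, a higher number a weaker inhibitor), where compound 1 gives 12.3 nM. Among the measured compounds shown here, of the two numbers known so far this is the lower one, though its nearest neighbour, compound 2 `COc1ccc(S(=O)(=O)NCCN2CCC(CCC(=O)c3cc(Cl)c(N)cc3OC)CC2)c(OC)c1`, lies within the usual scatter: in this assay compound 2 gives 18.7 nM, and the step of a 1.5-fold higher number from compound 1 to compound 2 (0.18 log units; within the scatter) is therefore too small to be read as a real difference.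

Compound 3 `COc1cc(N)c(Cl)cc1C(=O)CCC1CCN(CCNS(=O)(=O)c2ccc(OC)c(N3CCN(C)CC3)c2)CC1` has not yet been measured. It differs from compound 1 in one place: 4-methylpiperazin-1-yl in place of hydrogen on an aromatic carbon. For the measured compounds named here, the only measured step that bears on this change is the one from compound 1 to compound 2, which also added a substituent on an aromatic carbon of the sulfonamide-bearing ring, and that step of a 1.5-fold higher number from compound 1 to compound 2 (0.18 log units; within the scatter) stayed within the scatter. The group entering here is larger, but nothing measured suggests a large shift in either direction. In this assay compound 3 is therefore expected to give about 20 nM, with a likely range from 7 nM to 60 nM, a step of a 1.6-fold higher number from compound 1 to compound 3 (0.21 log units; within the scatter) that is expected to remain small.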

Compound 3, inhibition constant: 3.46 nM
Estimate against measurement, compound 3: 5.8-fold (0.76 log units) above, outside the stated range (below it).
By their numbers in this assay, from the lowest: compound 3; then compounds 1 and 2 (each within the scatter of the next).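

In this assay, among the compounds shown here, the step of a 3.6-fold lower number from compound 1 to compound 3 (0.55 log units; beyond the scatter) is the first one in this small set that lies beyond the scatter, and it goes toward a stronger inhibitor. It shows that the aromatic carbon ortho to a methoxy group accepts a large group carrying a six-membered non-aromatic ring, with no loss of binding and a measurable gain, whereas the step of a 1.5-fold higher number from compound 1 to compound 2 (0.18 log units; within the scatter) placed a methoxy in place of hydrogen and gave no readable change. Nothing among the available data speaks to why the 4-methylpiperazin-1-yl group gives this result.

The compounds shown leave open which part of the 4-methylpiperazin-1-yl group matters: a piperazin-1-yl group without the methyl, a morpholine ring or an open-chain dimethylamino group on the same carbon would begin to separate the contributions of the ring, its nitrogen atoms and the methyl. They also leave open whether the gain survives if the methoxy group to which the new group is ortho gives way to hydrogen or to an ethoxy group.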